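Moving the pyridine nitrogen on an oxazole ketone

The source may hold more compounds than are shown below. What is called first, only, known or untested is meant among the compounds shown, and "the series" means these compounds.

Compound 1 `O=C(CCCCCCc1ccccc1)c1nc(C(F)(F)F)co1`: 214 nM
Compound 2 `CS(=O)(=O)c1coc(C(=O)CCCCCCc2ccccc2)n1`: 389 nM
Compound 3 `O=C(CCCCCCc1ccccc1)c1nc(-c2ccccn2)co1`: > 10000 nM, a limit of the assay

In an assay on HEK-293T cells for inhibition of diacylglycerol lipase-alpha (Homo sapiens), read by colorimetric assay (on this read-out lower numbers stand for stronger inhibition and higher numbers for weaker inhibition), compound 3 stands at the assay limit (the limit of > 10000 nM in this assay, at which 1 of the 3 values shown sits), so only a limit and no number is known for it. Compound 4 `O=C(CCCCCCc1ccccc1)c1nc(-c2ccncc2)co1` differs from it by pyridin-4-yl in place of pyridin-2-yl on an aromatic carbon. For the measured compounds named here, the steps that bear on this change are an at least 46-fold higher number from compound 1 to compound 3 (1.66 log units; beyond the scatter) and an at least 25-fold higher number from compound 2 to compound 3 (1.41 log units; beyond the scatter), both large, which place a pyridin-2-yl group at this position past the limit. Compound 4 keeps a pyridinyl ring there, with the same atoms joined differently, so no step beyond the scatter is expected. The expected step is a step that the limit leaves unreadable from compound 3 to compound 4. Compound 4 is estimated at 15000 nM, in a range from 4000 nM to 60000 nM, most likely again reported only as a limit.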

Compound 4, half-maximal inhibitory concentration: > 10000 nM
Compound 4 was reported as a limit; the forecaster's own chance of this, stated with the estimate: 70%; the middle value does not contradict the limit.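

In this assay, compound 4 also stands at a limit, so placing the ring nitrogen as in pyridin-4-yl rather than pyridin-2-yl does not restore a readable number: the limit of > 10000 nM in this assay, at which 2 of the 4 values shown sit. Both pyridine compounds therefore lie far from the trifluoromethyl and methylsulfonyl compounds, with an at least 46-fold higher number from compound 1 to compound 4 (1.66 log units; beyond the scatter) and an at least 25-fold higher number from compound 2 to compound 4 (1.41 log units; beyond the scatter).

On these data alone, the step between the two pyridine compounds cannot be read, so their order and their true values remain unknown. As far as these compounds go, it also remains open whether pyridin-3-yl, a nitrile or an amine at this position would give a readable number.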